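Straightening a Branched Chain on the Shared Core

A few compounds are considered here, and "the series" means these few. Any claim that something is new, unique, unknown or untested is made for them only; others in the source may bear on it.

Among the measured compounds shown here, compound 2 `CC(C)CNc1nnc(SCC(=O)N(Cc2cccc([N+](=O)[O-])c2)c2ccc(F)cc2)s1` is one of two compounds measured so far in an assay on isolated protein for inhibition of Amine oxidase [flavin-containing] A (Homo sapiens), read by fluorescence and Amplex Red, with a stated time of 30 min, tested at 0.01 nM (a lower number here means a weaker effect, a higher number a stronger effect of the compound at the concentration tested), and in this assay compound 2 gives 6.36%. For the measured compounds named here, the only other measured compound is compound 1 `CCNc1nnc(SCC(=O)N(Cc2cccc([N+](=O)[O-])c2)c2ccc(F)cc2)s1`, which in this assay gives 10.3%; the two numbers lie within the usual scatter of one another. Going by the values given here, the single measured step, a number 3.9 percentage points lower from compound 1 to compound 2 (within the scatter), altered the chain on the same saturated carbon and did not move the read-out beyond the scatter. Both compounds show little effect at the concentration tested.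

Compound 3 `CCCCNc1nnc(SCC(=O)N(Cc2cccc([N+](=O)[O-])c2)c2ccc(F)cc2)s1` has not yet been measured. It differs from compound 2 in one place: propyl in place of isopropyl on a saturated chain carbon bound to a nitrogen on an aromatic ring. The same atoms are present, joined differently.

The step from compound 1 to compound 2 is the only one that bears on this change, and it was within the scatter, so no move beyond the scatter is expected here either. The step of a number 1.6 percentage points higher from compound 2 to compound 3 (within the scatter) is therefore expected to be small. Compound 3 is estimated at 8%, with a range from 0% to 20%.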

Compound 3, a percentage reported as inhibition, at one concentration (the size of the read-out at that concentration, not a potency): 6.94%
The estimate for compound 3 lay 1.1 percentage points above the measured number; low and high end bracket the measured number.
By their numbers in this assay, from the lowest: compounds 2, 3 and 1 (each within the scatter of the next).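

In this assay, joining the same atoms as propyl in place of isopropyl gives a number 0.6 percentage points higher from compound 2 to compound 3 (within the scatter), so at the concentration tested, removing the branch from this chain leaves the read-out within the scatter. The earlier step had altered the chain only by adding a branch, whereas the ethyl in place of hydrogen on a saturated chain carbon, two bonds along the chain from a nitrogen on an aromatic ring, gives a number 3.4 percentage points lower from compound 1 to compound 3 (within the scatter), which shows that this unbranched extension also stays within the scatter. Across these three compounds, neither the branched nor the straight form separates from the others, and no outside information is available to explain this.

Going by these compounds, all three compounds carry a small saturated carbon chain at this position, so it remains open whether a longer chain such as octyl, a cyclohexyl ring, or a chain ending in an amine or a carboxylic acid would move the read-out beyond the scatter. On these data alone, since each number is a read-out at one concentration and not a potency, how these compounds would compare at higher concentrations also remains open.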